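Trifluoromethylphenyl positional scan and a dichlorophenyl follow-up

The compounds below may be only part of what the source reports. "The series", "measured", "known", "first", "only" and "open" are said of these compounds alone.

Measured so far:
compound 1 `CC/C(=C(/c1ccc(/C=C/C(=O)O)cc1)c1cc2ccccc2[nH]1)c1ccccc1C(F)(F)F`: 8 nM
compound 2 `CC/C(=C(/c1ccc(/C=C/C(=O)O)cc1)c1cc2ccccc2[nH]1)c1cccc(C(F)(F)F)c1`: 325 nM
compound 3 `CC/C(=C(/c1ccc(/C=C/C(=O)O)cc1)c1cc2ccccc2[nH]1)c1ccc(C(F)(F)F)cc1`: 139 nM

Working notes. In a functional assay on MCF7 cells (Homo sapiens) for inhibition (on this read-out higher numbers stand for weaker inhibition and lower numbers for stronger inhibition), compound 3 gives the second highest of the three numbers; its nearest neighbour is compound 2 (a 2.3-fold lower number from compound 2 to compound 3 (0.37 log units; beyond the scatter)), while compound 1 lies far away (a 17-fold higher number from compound 1 to compound 3 (1.24 log units; beyond the scatter)). Compound 4 `CC/C(=C(/c1ccc(/C=C/C(=O)O)cc1)c1cc2ccccc2[nH]1)c1ccc(Cl)cc1Cl` is not yet measured in this assay; it differs from compound 3 by 2,4-dichlorophenyl in place of 4-(trifluoromethyl)phenyl on a double-bonded chain carbon bound to a double-bonded chain carbon and a saturated chain carbon.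

The bearing steps are the three positional swaps on this same phenyl: a 41-fold higher number from compound 1 to compound 2 (1.61 log units; beyond the scatter), a 17-fold higher number from compound 1 to compound 3 (1.24 log units; beyond the scatter) and a 2.3-fold lower number from compound 2 to compound 3 (0.37 log units; beyond the scatter). They show that where the substituent sits on this ring governs the number far more than the scatter, and that the 2-(trifluoromethyl)phenyl pattern of compound 1 gives the lowest number. The entering 2,4-dichlorophenyl carries its name's substitution in part as compound 1 does and in part as compound 3 does. As far as these compounds go, compound 4 is therefore expected to fall below compound 3, with a 4.6-fold lower number from compound 3 to compound 4 (0.67 log units; beyond the scatter) estimated, because of a 17-fold higher number from compound 1 to compound 3 (1.24 log units; beyond the scatter); the chlorine-for-trifluoromethyl change is untested, so the range is wide. Estimate for compound 4 in this assay: 30 nM, range 8 nM to 120 nM.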

Compound 4, half-maximal inhibitory concentration: 11 nM
The estimate for compound 4 lay 2.7-fold (0.44 log units) above the measured number; measured number inside the range.
By their numbers in this assay, from the lowest: compounds 1 and 4 (each within the scatter of the next); then compound 3; then compound 2.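

In this assay, 2,4-dichlorophenyl on this double-bonded chain carbon gives a 13-fold lower number from compound 3 to compound 4 (1.10 log units; beyond the scatter) and a 30-fold lower number from compound 2 to compound 4 (1.47 log units; beyond the scatter), so trifluoromethyl is not required for a low number at this position. With a 1.4-fold higher number from compound 1 to compound 4 (0.14 log units; within the scatter), compound 1 and compound 4 cannot be ordered, and compound 1 no longer stands alone at the low end of the series. No measurement bears on why this exchange has so large an effect.

Still open, as far as these compounds go, is how much each chlorine contributes, which a 2-chlorophenyl or a 4-chlorophenyl group on this carbon would separate. Also open, from the compounds shown here alone, is whether a methoxy group or an amine on this phenyl would keep the number as low, and whether the low number depends on the carboxylic acid.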